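Removing a Methoxy Group from Two Related Amines

The compounds below may be only part of what the source reports. "The series", "measured", "known", "first", "only" and "open" are said of these compounds alone.

Compound 1 `COc1cccc2c1OCC(C)(C)C2N` and compound 2 `CC1(C)COc2ccccc2C1N` share a core and differ in one spot: hydrogen in place of methoxy on an aromatic carbon. In an assay on BTI cells for inhibition of Amine oxidase [flavin-containing] A (Homo sapiens), read by fluorescence, with a stated time of 20 min, tested at 1 uM (a higher number here means more inhibition at the concentration tested (going by the name of the read-out), a lower number less inhibition), compound 1 gives -0.7%, and compound 2 gives -3.8%, so that a number 3.1 percentage points lower from compound 1 to compound 2 (within the scatter). Compound 3 `C#CCN(Cc1ccccc1)C1c2cccc(OC)c2OCC1(C)C` carries a larger group on the nitrogen; how its core differs from that of compound 1 is not broken down here. In this assay compound 3 gives 4.3%, a number within the scatter of both compound 1 and compound 2.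

Compound 4 `C#CCN(Cc1ccccc1)C1c2ccccc2OCC1(C)C` has not yet been measured. It arises from compound 3 through the same change that turns compound 1 into compound 2: hydrogen in place of methoxy on an aromatic carbon. Among the four compounds this change occurs two times in all, and its one measured occurrence gave a number 3.1 percentage points lower from compound 1 to compound 2 (within the scatter). Resting on that, the step is expected to be a number 3.3 percentage points lower from compound 3 to compound 4 (within the scatter), similar in size to the earlier one. Compound 4 is therefore estimated at 1% in this assay, with most repeat measurements expected between -8% and 10%.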

Compound 4, a percentage reported as inhibition, at one concentration (the size of the read-out at that concentration, not a potency): -10.6%
Compound 4: middle estimate off by 11.6 percentage points, on the high side; the measured number lies below the stated range.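

Replacing methoxy with hydrogen on the core of compound 3 gives a number 14.9 percentage points lower from compound 3 to compound 4 (beyond the scatter) in this assay, a step large enough to read on its own, unlike the earlier one. Set side by side, however, the two steps cannot be told apart: the same change on two cores in this assay, a number 3.1 percentage points lower (within the scatter) from compound 1 to compound 2 and a number 14.9 percentage points lower (beyond the scatter) from compound 3 to compound 4, 11.8 percentage points apart, within the scatter of two such steps. The change therefore points the same way on both cores, and the data give no firm sign that the core alters its size, but two pairs cannot show that it carries over by a fixed amount, so the larger step on this core may or may not hold up on repeat measurement.

Among the compounds shown, only methoxy and hydrogen occupy this aromatic carbon, so it remains open how a hydroxyl group, a chlorine atom or a longer ethoxy chain would behave there. Each number also comes from a single concentration, which leaves the potency of all these compounds open.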